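Para substituent swap on the shared core: hydroxy to trifluoromethyl

This account rests on a few compounds, and the source may have more. Where it says the series, first, only, none or still open, it means among the compounds named here.

Compound 1 `Brc1ccc(-c2nc3ccccn3c2NC2CCCCC2)cc1` gives 3900 nM in an assay on membranes from brain for displacement of a labelled ligand from adenosine receptor A1 (Rattus norvegicus); a lower number here means a stronger inhibitor, a higher number a weaker inhibitor. Compound 2 `O=[N+]([O-])c1ccc(-c2nc3ccccn3c2NC2CCCCC2)cc1` reaches only the limit > 100000 nM in this assay, a limit and not a number (the limit of > 100000 nM in this assay, at which 1 of the 3 values shown sits). Compound 3 `Oc1ccc(-c2nc3ccccn3c2NC2CCCCC2)cc1` gives 5530 nM, the highest of the two numbers shown, with compound 1 nearest at a 1.4-fold higher number from compound 1 to compound 3 (0.15 log units; within the scatter). Compound 4 `FC(F)(F)c1ccc(-c2nc3ccccn3c2NC2CCCCC2)cc1` differs from compound 3 by trifluoromethyl in place of hydroxy on an aromatic carbon. For the measured compounds named here, two measured steps bear on this position: the change a 1.4-fold higher number from compound 1 to compound 3 (0.15 log units; within the scatter), and the change an at least 18-fold lower number from compound 2 to compound 3 (1.25 log units; beyond the scatter). Substituents at this carbon thus span from modest to very large effects, so compound 4 is expected near compound 3 with a wide band, a 1.3-fold higher number from compound 3 to compound 4 (0.10 log units; within the scatter). Compound 4 is therefore estimated at 7000 nM, between 2000 nM and 40000 nM.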

Compound 4, inhibition constant: > 100000 nM
Compound 4 gave a limit, no number; the forecaster's own chance of this, stated with the estimate: 10%; middle value at least 14-fold (1.15 log units) from the limit.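

In this assay, trifluoromethyl on this aromatic carbon brought an at least 18-fold higher number from compound 3 to compound 4 (1.25 log units; beyond the scatter), and in place of bromo it brought an at least 25-fold higher number from compound 1 to compound 4 (1.40 log units; beyond the scatter). Nitro is therefore no longer the only group here with such a large step, and the four groups fall into two pairs, with bromo and hydroxy giving numbers and the other two giving none. Compound 2 and compound 4 each stand at a limit, so the step between them cannot be read: the limit of > 100000 nM in this assay, at which 2 of the 4 values shown sit.

The compounds shown leave open whether an amine, a methoxy group or a carboxylic acid on this carbon would give a number, as bromo and hydroxy do, or a limit, as nitro and trifluoromethyl do.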